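A few compounds are considered here, and "the series" means these few. Any claim that something is new, unique, unknown or untested is made for them only; others in the source may bear on it.

Compound 1 `O=C(Nc1cc(Br)cc2c(=O)cc(C(=O)O)oc12)c1ccc(Cl)c(Cl)c1`: 3250 nM
Compound 2 `COc1ccc(C(=O)Nc2cc(Br)cc3c(=O)cc(C(=O)O)oc23)cn1`: 991 nM

Among the measured compounds shown here, in an assay on CHO cells for agonist activity at G protein-coupled receptor GPR35 (Rattus norvegicus), read by a beta-galactosidase reporter and beta-arrestin recruitment, with a stated time of 90 min (a higher number here means that more compound is needed for the effect, a lower number that less compound is needed), compound 2 gives 991 nM, the lowest of the two numbers so far. The nearest is compound 1, which in this assay gives 3250 nM. For the measured compounds named here, the single measured step, a 3.3-fold lower number from compound 1 to compound 2 (0.52 log units; beyond the scatter), shows that exchanging the aromatic group on the carbonyl carbon can shift the number by a modest but real amount.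

Compound 3 `COc1ccccc1C(=O)Nc1cc(Br)cc2c(=O)cc(C(=O)O)oc12` has not yet been measured in this assay. It differs from compound 2 by 2-methoxyphenyl in place of 6-methoxypyridin-3-yl on a carbonyl carbon. The step from compound 1 to compound 2 bears on it only loosely: it concerns the same place in the molecule but a different pair of groups, so it indicates the likely scale of a change rather than its direction. With a methoxy-bearing aromatic ring still attached to the carbonyl carbon, the step from compound 2 to compound 3 is expected to be about a 1.8-fold higher number from compound 2 to compound 3 (0.26 log units; within the scatter), that is, little more than the scatter, with a slight rise somewhat more likely than a fall. Compound 3 is therefore estimated at 1800 nM, within a range from 600 nM to 5500 nM.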

Compound 3, half-maximal effective concentration: 1100 nM
For compound 3 the middle estimate is 1.6-fold (0.21 log units) above the measured one, and the stated range covers the measured number.
By their numbers in this assay, from the lowest: compounds 2 and 3 (each within the scatter of the next); then compound 1.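

In this assay, a change of ring type on the carbonyl carbon leaves no readable trace: replacing 6-methoxypyridin-3-yl, a ring with one hetero atom, with 2-methoxyphenyl, a ring of carbon only, gives a 1.1-fold higher number from compound 2 to compound 3 (0.05 log units; within the scatter) and so stays inside the usual scatter. The comparison with 3,4-dichlorophenyl also gains a second case, for a 3.0-fold lower number from compound 1 to compound 3 (0.47 log units; beyond the scatter) now stands alongside a 3.3-fold lower number from compound 1 to compound 2 (0.52 log units; beyond the scatter) and both lie beyond the scatter, so two different methoxy-bearing rings on this carbonyl carbon give numbers clearly lower than compound 1 does. No evidence on the cause of these results is available.

The compounds shown do not separate the methoxy group from the ring that carries it, and they leave open what a plain phenyl ring, or an amine or a carboxylic acid on that ring, would give. They also do not say whether a longer chain in place of the aromatic ring on the carbonyl carbon would keep the number in this range, or whether these steps would hold with the shared core altered elsewhere.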